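Aryl urea series: heptyl to trifluoromethyl

The compounds below may be only part of what the source reports. "The series", "measured", "known", "first", "only" and "open" are said of these compounds alone.

Compound 3 `CCCCCCCc1ccc(NC(=O)N[C@H](C)c2ccccc2)cc1` gives 100% in an ADME assay on the whole organism with Oryza sativa as the target, tested at 0.1 uM; on this read-out higher numbers stand for a weaker effect at the one concentration tested and lower numbers for a stronger effect. It stands level with compound 2 `CCCCCc1ccc(NC(=O)N[C@H](C)c2ccccc2)cc1`, which gives 100%, the two together the highest of the three numbers; the step of no change at the digits printed from compound 2 to compound 3 (within the scatter) lies within the scatter. Compound 1 `CCCc1ccc(NC(=O)N[C@H](C)c2ccccc2)cc1` gives 33%, the lowest number, and the steps of a number 67 percentage points higher from compound 1 to compound 2 (beyond the scatter) and a number 67 percentage points higher from compound 1 to compound 3 (beyond the scatter) are both large and beyond the scatter.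

Compound 4 `C[C@@H](NC(=O)Nc1ccc(C(F)(F)F)cc1)c1ccccc1` is not yet measured. It differs from compound 3 in one place: trifluoromethyl in place of heptyl on an aromatic carbon. Among the compounds with values here, no measured step exchanges an alkyl chain for trifluoromethyl, so none bears on it directly. The measured steps show that going from propyl to pentyl raised the number strongly, while going further to heptyl changed nothing; the present change runs the other way, removing the longest chain in favour of a group of a different kind. On that ground a lower number than compound 3 gives is expected in this assay, though its size is uncertain, since compound 1 is the only point away from the high level. The step is estimated as a number 45 percentage points lower from compound 3 to compound 4 (beyond the scatter). For compound 4 the estimate is 55%, with a range from 20% to 100%.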

Compound 4, a percentage reported as activity, at one concentration (the size of the read-out at that concentration, not a potency): 93%
For compound 4 the middle estimate is 38 percentage points below the measured one; low and high end bracket the measured number.
By their numbers in this assay, from the lowest: compound 1; then compounds 4, 2 and 3 (each within the scatter of the next).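

In this assay the exchange of heptyl for trifluoromethyl on the aromatic carbon gives a number 7 percentage points lower from compound 3 to compound 4 (within the scatter), and the exchange of pentyl for trifluoromethyl gives a number 7 percentage points lower from compound 2 to compound 4 (within the scatter), so a long alkyl chain at this position is not required for the high level. The exchange of propyl for trifluoromethyl gives a number 60 percentage points higher from compound 1 to compound 4 (beyond the scatter), which leaves the propyl analogue alone away from the high level among these four compounds. No measurement at hand accounts for the propyl analogue standing apart from the trifluoromethyl, pentyl and heptyl analogues.

From the compounds shown here alone, whether the low number belongs to propyl alone remains open, as butyl, ethyl, methyl and plain hydrogen at this position would be needed to tell. Also open, going by these compounds, is how an amine or a carboxylic acid on this aromatic carbon would read out.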